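This account rests on a few compounds, and the source may have more. Where it says the series, first, only, none or still open, it means among the compounds named here.

Compound 1 `CN(c1cccc2c1CN(c1nc(Nc3ccc(C(F)(F)F)cc3)ncc1C(F)(F)F)C2)S(C)(=O)=O` is the starting point of this comparison. In a functional assay on HeLa cells (Homo sapiens) for antiproliferative activity, read by spectrophotometry, with a stated time of 2 days (on this read-out lower numbers stand for stronger inhibition of growth and higher numbers for weaker inhibition of growth), compound 1 gives only a limit, > 30000 nM, so no number is known for it, and all that can be said of it is the limit of > 30000 nM in this assay, at which 1 of the 3 values shown sits. Compound 2 `CN(c1cccc2c1CN(c1nc(Nc3ccc(Cl)c(C(F)(F)F)c3)ncc1C(F)(F)F)C2)S(C)(=O)=O` gives 11100 nM in this assay, and compound 3 `COc1ccc(C(F)(F)F)cc1Nc1ncc(C(F)(F)F)c(N2Cc3cccc(N(C)S(C)(=O)=O)c3C2)n1` gives 17200 nM. The step from compound 1 to compound 2 is an at least 2.7-fold lower number from compound 1 to compound 2 (0.43 log units; beyond the scatter), the step from compound 1 to compound 3 is an at least 1.7-fold lower number from compound 1 to compound 3 (0.24 log units; that floor lies within the scatter), and between compound 2 and compound 3 the difference is a 1.5-fold higher number from compound 2 to compound 3 (0.19 log units; within the scatter). Each of these steps exchanges the group on a nitrogen on an aromatic ring, and none of them moves the number far.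

Compound 4 `CC(=O)N1CCN(c2ccc(Nc3ncc(C(F)(F)F)c(N4Cc5cccc(N(C)S(C)(=O)=O)c5C4)n3)cc2)CC1` differs from compound 1 by 4-acetylpiperazin-1-yl in place of trifluoromethyl on an aromatic carbon. Among the measured compounds shown here, no measured step makes a change of this kind on an aromatic carbon para to a large group, so the three measured steps bear on it only indirectly: they show that changes on this part of compound 1 have so far given at most modest movement. The change to compound 4 is larger in what it adds than any measured step, so a somewhat larger movement toward lower numbers is expected, though the measured compounds cannot fix its direction with confidence. Compound 4 is therefore expected to give about 8000 nM, within a range of 2000 nM to 30000 nM. This estimate means an expected step of an at least 3.7-fold lower number from compound 1 to compound 4 (0.57 log units; beyond the scatter).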

Compound 4, concentration for 50% growth inhibition: 730 nM
For compound 4 the middle estimate is 11-fold (1.04 log units) above the measured one; measured number outside the range, below it.
By their numbers in this assay, from the lowest: compound 4; then compounds 2 and 3 (each within the scatter of the next). At a limit, above all of these: compound 1.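

In this assay, the exchange of trifluoromethyl for 4-acetylpiperazin-1-yl on an aromatic carbon para to a large group gives an at least 41-fold lower number from compound 1 to compound 4 (1.61 log units; beyond the scatter), so this position responds far more strongly than the earlier exchanges suggested, the clearest of which gave an at least 2.7-fold lower number from compound 1 to compound 2 (0.43 log units; beyond the scatter). The entering group brings one six-membered non-aromatic ring with 2 hetero atoms and 2 hydrogen-bond acceptors, while the leaving trifluoromethyl has no ring and no hydrogen-bond acceptors, but this single change cannot show which of these features goes with the step. The size of the step is only a floor because compound 1 gives a limit and not a number: the limit of > 30000 nM in this assay, at which 1 of the 4 values shown sits.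

On these data alone, how a piperazine with a free ring nitrogen, a morpholine or a simple dimethylamino group would behave at this carbon remains open, and so does the part played by the acetyl group. As far as these compounds go, it is also open whether 4-acetylpiperazin-1-yl would give a step of similar size alongside the chloro or methoxy groups of compound 2 and compound 3.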